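The source may hold more compounds than are shown below. What is called first, only, known or untested is meant among the compounds shown, and "the series" means these compounds.

Measured compounds in a functional assay on DU-145 cells (Homo sapiens) for inhibition, read by trypan blue exclusion, with a stated time of 96 h; on this read-out higher numbers stand for weaker inhibition of growth and lower numbers for stronger inhibition of growth:
Compound 1 `Cc1ccc(CS/C(=C/c2ccc(C)s2)C(=O)c2ccc(Cl)cc2)cc1` gives 50000 nM.
Compound 3 `Cc1ccc(CS/C(=C/c2sccc2C)C(=O)c2ccc(Cl)cc2)cc1` gives 10000 nM.
Compound 2 `Cc1ccc(CS/C(=C/c2ccc(N(C)C)cc2)C(=O)c2ccc(Cl)cc2)cc1` gives > 100000 nM, which is a limit of the assay and not a number.

Compound 1 stands highest of the two numbers shown; the step of a 5.0-fold lower number from compound 1 to compound 3 (0.70 log units; beyond the scatter) lies beyond the scatter, and the step of an at least 2.0-fold higher number from compound 1 to compound 2 (0.30 log units; that floor lies within the scatter) runs into a limit. Compound 4 `Cc1ccc(/C=C(/SCc2ccc(Cl)cc2)C(=O)c2ccc(Cl)cc2)s1` differs from compound 1 by chloro in place of methyl on an aromatic carbon. Every measured step changes the group on the double-bonded chain carbon instead, so none of them bears on the benzyl ring where the change occurs. He therefore expects no step beyond the scatter, no change at the digits printed from compound 1 to compound 4 (within the scatter). Compound 4 is estimated at 50000 nM, within 20000 nM to 100000 nM.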

Compound 4, concentration for 50% growth inhibition: 50000 nM
Beside the measured number, compound 4's estimate shows no gap at the digits printed; measured number inside the range.
By their numbers in this assay, from the lowest: compound 3; then compounds 1 and 4 (each within the scatter of the next). At a limit, above all of these: compound 2.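

Among these compounds, the earlier steps all changed the group on the double-bonded chain carbon; here, 4-chlorobenzyl in place of 4-methylbenzyl gives no change at the digits printed from compound 1 to compound 4 (within the scatter) in this assay, the first reading at this ring position. For this one pair, chloro and methyl at the carbon para to a large group cannot be told apart. Nothing in the data shown accounts for this result.

The compounds shown leave open how a methoxy group or an amine would read at this carbon. They also leave open whether the same swap would read alike with the 3-methylthiophen-2-yl group of compound 3 in place.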